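A Smaller Aryl Group on the Ring Amine Nitrogen

The source may report more compounds than this note shows. Statements on the series, on what has been measured and on what is new or still open speak of the compounds shown alone.

Compound 1, `Cc1cccc2c1CCN2CCNC(=O)Nc1ccccc1Br`, 7.4
Compound 2, `Cc1ccc(N2CC[C@@H](NC(=O)Nc3ccccc3Br)C2)cc1F`, 8.3
Compound 3, `Cc1ccc2c(c1)CCN2CCNC(=O)Nc1ccccc1Br`, 7.3

These three ureas were tested in a functional assay for antagonist activity at transient receptor potential cation channel subfamily V member 1 (Rattus norvegicus), read by FLIPR; on this read-out higher numbers stand for higher potency (the scale is a negative logarithm) and lower numbers for lower potency. Compound 2 gives 8.3, the highest of the three numbers. Compound 1 gives 7.4, a step down from compound 2 that lies beyond the scatter, and compound 3 gives 7.3, a slightly larger step down that also lies beyond the scatter. On these numbers compound 2 is the most potent of the set.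

Compound 4, `Cc1cccc(N2CC[C@@H](NC(=O)Nc3ccccc3Br)C2)c1`, has not yet been measured in this assay. It differs from compound 2 in one place: 3-methylphenyl in place of 3-fluoro-4-methylphenyl on an amine nitrogen in a ring. For the measured compounds named here, no pair of measured compounds differs in this way, and compounds 1 and 3 are built on other cores, so they do not show how this assay responds to the aryl group on the ring amine nitrogen.

The account therefore rests on compound 2 alone. The change removes the fluorine and shifts the methyl, while the rest of the molecule is kept, so a modest downward step, near the edge of the scatter, is expected, giving an estimated step of a number 0.40 log units lower from compound 2 to compound 4 (beyond the scatter) in this assay. Compound 4 is accordingly expected to give about 7.9, within a range of 7.3 to 8.5.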

Compound 4, negative logarithm of the antagonist equilibrium constant in the transient receptor potential cation channel subfamily V member 1 assay: 7.7
Beside the measured number, compound 4's estimate is 0.20 log units above it; the measured number falls inside the stated range.
By their numbers in the transient receptor potential cation channel subfamily V member 1 assay, from the lowest: compounds 3, 1 and 4 (each within the scatter of the next, the first and the last beyond it); then compound 2.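

For the compounds shown here, in the transient receptor potential cation channel subfamily V member 1 assay, the change gives a number 0.60 log units lower from compound 2 to compound 4 (beyond the scatter), the first measured step at this position, and it shows that the assay responds to the aryl group on the amine nitrogen of the five-membered ring, which compounds 1 and 3, built on other cores, could not show. Going by these compounds alone, the single step combines two differences, the loss of the fluorine and the different placing of the methyl, so it shows the effect of exchanging 3-fluoro-4-methylphenyl for 3-methylphenyl as a whole and does not divide that effect between them. In a physicochemical assay for solubility (on this read-out lower numbers stand for lower solubility and higher numbers for higher solubility), compound 2 gives < 100 ug/mL, which is a limit of the assay and not a number. In the physicochemical assay, compound 4 gives < 100 ug/mL, which is also a limit of the assay and not a number. In the physicochemical assay, no step can be read for this change because both compounds stand at a limit of the assay, not at a number: the limit of < 100 ug/mL in the physicochemical assay, at which 2 of the 2 values shown sit.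

The compounds shown leave open which of the two differences carries the step in the transient receptor potential cation channel subfamily V member 1 assay, and how an unsubstituted phenyl group, a pyridine ring or a methoxy or chlorine substituent on the aryl ring would compare at this position. They also leave open whether any such group would give a readable number in the physicochemical assay.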